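A few compounds are considered here, and "the series" means these few. Any claim that something is new, unique, unknown or untested is made for them only; others in the source may bear on it.

Measured so far in a functional assay on COR-L23 cells (Homo sapiens) for antiproliferative activity, read by CellTiter-Glo, with a stated time of 72 h; a lower number here means a stronger inhibitor, a higher number a weaker inhibitor:
- compound 1 `C[C@H](NC(=O)c1cccc(F)c1)c1ccc(NC(=O)N2CC(c3cccnc3)C2)cc1` gives 10 nM
- compound 2 `C[C@H](NC(=O)c1cccc(F)c1)c1ccc(NC(=O)N2CC(c3ccc(N)nc3)C2)cc1` gives 27 nM
- compound 3 `C[C@H](NC(=O)[C@@H]1CCCN1C)c1ccc(NC(=O)N2CC(c3ccc(N)nc3)C2)cc1` gives 41 nM

Compound 2 lies within the scatter of compound 3, while compound 1 holds a lower number, beyond the scatter. Still unmeasured is compound 4 `C[C@H](NC(=O)c1cccc(F)c1)c1ccc(NC(=O)N2CC(c3cncc(N)c3)C2)cc1`, which has the same atoms as compound 2, joined differently: 5-aminopyridin-3-yl in place of 6-aminopyridin-3-yl on a saturated ring carbon. In words, 5-aminopyridin-3-yl stands in place of 6-aminopyridin-3-yl on a saturated ring carbon.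

The closest evidence is a 2.7-fold higher number from compound 1 to compound 2 (0.43 log units; beyond the scatter), with amino in place of hydrogen on an aromatic carbon, a modest step beyond the scatter. The other measured step, a 1.5-fold higher number from compound 2 to compound 3 (0.18 log units; within the scatter), lies within the scatter and concerns the group on a carbonyl carbon, so it says little about this change. Among the compounds with values here, no measured pair shows the amino group changing place, so the data give no firm direction. In this assay no step beyond the scatter is therefore expected, and the number for compound 4 should stay near that of compound 2 at 27 nM. The expected step is a 1.2-fold lower number from compound 2 to compound 4 (0.09 log units; within the scatter), and its direction is uncertain. Compound 4 is estimated at 22 nM, with an expected range from 8 nM to 60 nM.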

Compound 4, half-maximal inhibitory concentration: 630 nM
Estimate against measurement, compound 4: 29-fold (1.46 log units) below; measured number above the stated range.
By their numbers in this assay, from the lowest: compound 1; then compounds 2 and 3 (each within the scatter of the next); then compound 4.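

Working notes on the amino group: in this assay, the 5-aminopyridin-3-yl isomer sets apart two compounds with the same atoms, a 23-fold higher number from compound 2 to compound 4 (1.37 log units; beyond the scatter), so on this saturated ring carbon the placement of the amino group weighs heavily, which compounds 1 to 3 could not show. Amino in place of hydrogen on the six-membered aromatic ring gives a 2.7-fold higher number from compound 1 to compound 2 (0.43 log units; beyond the scatter) as 6-aminopyridin-3-yl, but a 63-fold higher number from compound 1 to compound 4 (1.80 log units; beyond the scatter) as 5-aminopyridin-3-yl, so the modest step first seen for this substitution does not hold for the amino group in general. Nothing measured on these compounds accounts for the gap between the two isomers.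

Still open, going by these compounds, is whether a hydroxyl or a methyl group in place of the amino group of 5-aminopyridin-3-yl would follow the same course, or whether the amino group itself drives the result. Also open, on these data alone, is whether the same isomer change would carry over with 1-methylpyrrolidin-2-yl on the carbonyl carbon, as in compound 3.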